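The source may hold more compounds than are shown below. What is called first, only, known or untested is meant among the compounds shown, and "the series" means these compounds.

Compound 1 `COc1ccc(OC)c(CNC(=O)NS(=O)(=O)c2ccc(Cl)cc2)c1`: > 300000 nM (a limit)
Compound 2 `COc1ccc(OC)c(CNC(=O)NS(=O)(=O)c2ccccc2)c1`: > 300000 nM (a limit)

Both entries come from a functional assay on thoracic aorta (Rattus norvegicus, strain Wistar), with a stated time of 15 min (a lower number here means that less compound is needed, a higher number that more compound is needed for the effect), and neither is a number. Compound 1 stands at the limit of > 300000 nM in this assay, at which 2 of the 2 values shown sit, so no measured potency exists for it, and the series offers no readable value to compare it with.

The next compound is compound 3 `COc1ccc(OC)c(CNC(=O)N(C)S(=O)(=O)c2ccc(Cl)cc2)c1`. It differs from compound 1 by methyl in place of hydrogen on an amide-type nitrogen whose other neighbours are the carbonyl carbon and the sulfonyl sulfur.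

For the measured compounds named here, only one measured step is available, a step that the two limits leave unreadable from compound 1 to compound 2. It concerns hydrogen in place of chloro on an aromatic carbon, so it is a different change and gives no size to carry over. Going by the values given here, no measured step touches the amide-type nitrogen.

In this assay, no readable step in either direction is therefore expected. The expectation rests on compound 1, whose value of > 300000 nM is a limit. The expected step is a number no higher from compound 1 to compound 3 (the limit leaves the size open). For compound 3 the estimated value is 300000 nM, with an expected range of 100000 nM to 1000000 nM.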

Compound 3, half-maximal effective concentration: 18200 nM
The estimate for compound 3 lay 16-fold (1.22 log units) above the measured number; the whole stated range lies above it.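

In this assay, methyl in place of hydrogen on the amide-type nitrogen gives an at least 16-fold lower number from compound 1 to compound 3 (1.21 log units; beyond the scatter). This makes compound 3, at 18200 nM, the only one of the three compounds shown with a number. The step also marks the amide-type nitrogen whose other neighbours are the carbonyl carbon and the sulfonyl sulfur as a place where one methyl moves the read-out clear of the limit, though the size of that step remains a bound and not an exact figure. The earlier change, hydrogen in place of chloro on an aromatic carbon, cannot be read, as compound 1 and compound 2 both sit at a limit and not at a number: the limit of > 300000 nM in this assay, at which 2 of the 3 values shown sit.

Still open, on these data alone, is whether ethyl or a longer chain on this nitrogen would lower or raise the number further, and whether a carboxylic acid or an amine at the end of such a chain would be tolerated. Also open, as far as these compounds go, is whether hydrogen in place of chloro on the aromatic carbon gives a readable step once the nitrogen carries methyl, and whether the entering methyl or the departing amide hydrogen matters more for the step.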